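A few compounds are considered here, and "the series" means these few. Any claim that something is new, unique, unknown or untested is made for them only; others in the source may bear on it.

In a functional assay (strain AB) with Danio rerio as the target, read by microscopy, with a stated time of 1 h (a higher number here means that more compound is needed for the effect, a lower number that less compound is needed), compound 1 `CCN1CCc2c(sc(NC(=O)Nc3ccc(I)cc3)c2C(N)=O)C1` gives 1620 nM. Compound 2 `CCN1CCc2c(sc(NC(=O)CN3CCCCC3)c2C(N)=O)C1` reads > 25000 nM, which is a limit of the assay and not a number. Compound 2 therefore stands at the limit of > 25000 nM in this assay, at which 1 of the 2 values shown sits. Going by the values given here, the single measured step is an at least 15-fold higher number from compound 1 to compound 2 (1.18 log units; beyond the scatter), and it lies beyond the scatter.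

Compound 3 `CCN1CCc2c(sc(NC(=O)c3ccccc3)c2C(N)=O)C1` differs from compound 2 in one place: phenyl in place of (piperidin-1-yl)methyl on a carbonyl carbon. Phenyl takes the place of (piperidin-1-yl)methyl on a carbonyl carbon whose other neighbour is an amide-type nitrogen. The measured step bears on this change, as it falls on the same carbonyl carbon and brings in the group that now leaves. The (4-iodophenyl)amino of compound 1 is not restored, so only part of that large step is expected to be recovered. The expected change in this assay is an at least 2.5-fold lower number from compound 2 to compound 3 (0.39 log units; beyond the scatter), in the direction of a lower number, and a result still at the limit would not be surprising. For compound 3 the estimate is 10000 nM, with an expected range from 3000 nM to 25000 nM.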

Compound 3, half-maximal effective concentration: > 25000 nM
Compound 3: a limit, no number; the forecaster's own chance of this, stated with the estimate: 40%; middle value at least 2.5-fold (0.39 log units) from the limit.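

In this assay compound 3 reads > 25000 nM, which is a limit of the assay and not a number. Phenyl in place of (4-iodophenyl)amino on the carbonyl carbon gives an at least 15-fold higher number from compound 1 to compound 3 (1.18 log units; beyond the scatter), so the loss at this position is no longer tied to (piperidin-1-yl)methyl alone: a second group, with an aromatic ring of carbon only in place of the non-aromatic ring, also fails to keep a readable value. Compound 2 and compound 3 both stand at limits, so the step between them cannot be read and the two groups cannot be ordered: the limit of > 25000 nM in this assay, at which 2 of the 3 values shown sit.

Compound 1 differs from compound 3 in both the amino nitrogen and the iodine, and the compounds shown do not tell which of the two goes with the result that compound 1 shows as 1620 nM here. Phenylamino without the iodine, or 4-iodophenyl set directly on the carbonyl carbon, would separate these two features.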